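Thiosemicarbazone series: aryl hydrazone changes and OVCAR-3 growth

The source may report more compounds than this note shows. Statements on the series, on what has been measured and on what is new or still open speak of the compounds shown alone.

Measured so far:
compound 1, `COc1ccc(/C=N\NC(=S)NC(C)(C)CCC[C@](C)(O)[C@@H]2CC=C(C)CC2)cc1`: 15800 nM
compound 2, `CC1=CC[C@@H]([C@@](C)(O)CCCC(C)(C)NC(=S)N/N=C\c2ccc(O)cc2)CC1`: 17400 nM
compound 3, `CC1=CC[C@@H]([C@@](C)(O)CCCC(C)(C)NC(=S)N/N=C\c2ccccc2Cl)CC1`: > 100000 nM

In a functional assay on OVCAR-3 cells (Homo sapiens) for cytotoxicity, read by sulforhodamine B assay (on this read-out lower numbers stand for stronger inhibition of growth and higher numbers for weaker inhibition of growth), compound 1 gives 15800 nM and compound 2 gives 17400 nM; the step of a 1.1-fold higher number from compound 1 to compound 2 (0.04 log units; within the scatter) is within the scatter. For compound 3 this assay reports only a limit, > 100000 nM, so compound 3 stands at the weak end of the three and the limit of > 100000 nM in this assay, at which 1 of the 3 values shown sits, is the only thing known of it. The steps of an at least 6.3-fold higher number from compound 1 to compound 3 (0.80 log units; beyond the scatter) and an at least 5.7-fold higher number from compound 2 to compound 3 (0.75 log units; beyond the scatter) are both beyond the scatter and point the same way.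

Compound 4, `CC1=CC[C@@H]([C@@](C)(O)CCCC(C)(C)NC(=S)N/N=C(/C)c2ccccc2)CC1`, is not yet measured. Its change from compound 3 is a group of 9 heavy atoms (8 carbon, 1 nitrogen; one six-membered aromatic ring of carbon only) in place of a group of 9 heavy atoms (7 carbon, 1 nitrogen, 1 chlorine; one six-membered aromatic ring of carbon only), on an amide-type nitrogen: the chlorine leaves with the outgoing group, and a methyl sits on the carbon with a double bond to nitrogen. Among the compounds with values here, no measured step covers either of those two changes on its own; the only steps that bear on it are those into compound 3, both at least modest and worsening. Since compound 3 is a limit, the size of the step to compound 4 cannot be read off; the expectation is a return toward compound 1 and compound 2 at most in part, so compound 4 is estimated to give 50000 nM (range 15000 nM to 150000 nM), which means an expected step of an at least 2.0-fold lower number from compound 3 to compound 4 (0.30 log units; that floor lies within the scatter).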

Compound 4, concentration for total growth inhibition: 59500 nM
Beside the measured number, compound 4's estimate is 1.2-fold (0.08 log units) below it; low and high end bracket the measured number.
By their numbers in this assay, from the lowest: compounds 1 and 2 (each within the scatter of the next); then compound 4. At a limit, above all of these: compound 3.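

Within the data shown here, replacing the group on the amide-type nitrogen with the one in compound 4, which has no chlorine and carries a methyl on the carbon with a double bond to nitrogen, gives a value that can be placed on the scale of this assay, whereas compound 3 remains a limit and not a number: the limit of > 100000 nM in this assay, at which 1 of the 4 values shown sits. From the compounds shown here alone, the change is recorded as an at least 1.6-fold lower number from compound 3 to compound 4 (0.22 log units; that floor lies within the scatter), so its true size stays unknown. The return is only partial, with a 3.4-fold higher number from compound 2 to compound 4 (0.53 log units; beyond the scatter) and a 3.8-fold higher number from compound 1 to compound 4 (0.58 log units; beyond the scatter), so the groups bearing 4-hydroxyphenyl and 4-methoxyphenyl keep numbers lower than this one.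

The methyl and the loss of chlorine arrive together, so their separate shares remain unresolved; a 4-methoxyphenyl group with that same methyl, or a plain phenyl group without it, would separate them. Also open, going by these compounds, is whether an amine or a carboxylic acid on the aromatic ring would match the oxygen-bearing groups, and whether fluorine in place of chlorine would give a result like that of the 2-chlorophenyl group.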